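The source may report more compounds than this note shows. Statements on the series, on what has been measured and on what is new or still open speak of the compounds shown alone.

In a functional assay on MDA-MB-231 cells (Homo sapiens) for inhibition, read by MTT assay, with a stated time of 48 h (on this read-out higher numbers stand for weaker inhibition and lower numbers for stronger inhibition), compound 1 `COc1cc(-c2cc(-c3ccc(Cl)cc3)nc(-c3ccccc3)n2)cc(OC)c1OC` gives > 25000 nM, which is a limit of the assay and not a number. Compound 2 `COc1cc(-c2cc(-c3ccc(Br)cc3)nc(-c3ccccc3)n2)cc(OC)c1OC` gives > 25000 nM, and this too is only a limit. Compound 2 therefore has no exact position on the scale. Going by the values given here, the one measured step, a step that the two limits leave unreadable from compound 1 to compound 2, puts bromo in place of chloro on an aromatic carbon, and its size cannot be read. All the evidence so far comes down to the limit of > 25000 nM in this assay, at which 2 of the 2 values shown sit.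

Compound 3 `COc1cc(-c2cc(-c3cccc([N+](=O)[O-])c3)nc(-c3ccccc3)n2)cc(OC)c1OC` differs from compound 2 by a new kind of change, 3-nitrophenyl in place of 4-bromophenyl on an aromatic carbon. Among the compounds with values here, no measured step covers such a swap, so the data give no size or direction for it. Within the data shown here, the only guide is the pair of limits, so the expectation is no step beyond the scatter, though a real gain in inhibition cannot be ruled out. The expected step runs an at least 1.2-fold lower number from compound 2 to compound 3 (0.09 log units; that floor lies within the scatter). For compound 3 the estimate is 20000 nM, with an expected range from 6000 nM to 50000 nM, and this assay may well report only a limit again.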

Compound 3, half-maximal inhibitory concentration: 2440 nM
The estimate for compound 3 lay 8.2-fold (0.91 log units) above the measured number; the measured number lies below the stated range.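

The position on the shared core that carried the 4-bromophenyl and 4-chlorophenyl groups can support measurable inhibition, which the two halogen compounds alone did not show. In this assay, 3-nitrophenyl at this place gives an at least 10-fold lower number from compound 2 to compound 3 (1.01 log units; beyond the scatter), and against the chloro partner it gives an at least 10-fold lower number from compound 1 to compound 3 (1.01 log units; beyond the scatter). Both steps start from a limit, so each sets only a floor on the size of the change, and compound 3 is the only compound here with an exact number against which further changes can be read: the limit of > 25000 nM in this assay, at which 2 of the 3 values shown sit.

The swap alters both the group on the phenyl ring and where that group stands, and the compounds shown do not separate these two changes, so it remains open whether the nitro group or its place on the ring goes with the gain. They also leave open how this assay would read with an amine or a carboxylic acid on the phenyl ring in place of the nitro group, and so whether the gain is particular to the nitro group.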